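This account rests on a few compounds, and the source may have more. Where it says the series, first, only, none or still open, it means among the compounds named here.

Compound 3 `Cc1ccc(S(=O)(=O)N2CCC(Br)=CC2CC(C)C)cc1` gives 36000 nM in a functional assay on A2780 cells (Homo sapiens) for antiproliferative activity, read by sulforhodamine B assay, with a stated time of 48 h (a higher number here means a weaker inhibitor of growth, a lower number a stronger inhibitor of growth), the lowest of the two numbers in hand. Compound 1 `CCCCCCCC1C=C(Cl)CCN1S(=O)(=O)c1ccc(C)cc1` gives 92000 nM in this assay, the nearest number and a higher one. Compound 2 `Cc1ccc(S(=O)(=O)N2CC=C(Br)CC2)cc1` reaches only the assay limit, > 100000 nM, in this assay. Among the compounds with values here, the one measured step in the set, an at least 2.7-fold lower number from compound 2 to compound 3 (0.44 log units; beyond the scatter), is the introduction of the isobutyl branch on a saturated ring carbon, and its size is a floor rather than a number because of the limit of > 100000 nM in this assay, at which 1 of the 3 values shown sits.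

Compound 4 `CCCCCCCC1C=C(Br)CCN1S(=O)(=O)c1ccc(C)cc1` differs from compound 3 by hexyl in place of isopropyl on a saturated chain carbon bound to a saturated ring carbon. Within the data shown here, no measured step lengthens this chain with the halogen held fixed. Compound 1 carries the same heptyl chain as compound 4 and a different halogen, and in this assay compound 1 gives 92000 nM where compound 3 gives 36000 nM, so the longer chain has not so far gone with a lower number. The step from compound 2 to compound 3 shows only that a branch at that carbon helps, not how far it may be extended. The expectation for compound 4 is therefore a modest rise, a 1.5-fold higher number from compound 3 to compound 4 (0.18 log units; within the scatter), close to the scatter. Compound 4 is estimated at 55000 nM, with a range from 22000 nM to 110000 nM.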

Compound 4, concentration for 50% growth inhibition: > 100000 nM
Compound 4: no number, only a limit (the forecaster's own chance of this, stated with the estimate: 15%); middle value at least 1.8-fold (0.25 log units) away from the limit.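

In this assay, within the data shown here, the new result reads an at least 2.7-fold higher number from compound 3 to compound 4 (0.44 log units; beyond the scatter), so on this saturated chain carbon bound to a saturated ring carbon, hexyl in place of isopropyl does not extend the benefit of the branch; the earlier compounds showed only that a substituent on the ring carbon could lower the number, not that a longer one could raise it again. The halogen step reads an at least 1.0-fold higher number from compound 1 to compound 4 (0.03 log units; that floor lies within the scatter), so with the heptyl chain in place no difference can be claimed for bromo in place of chloro on a double-bonded ring carbon, and the bromo and chloro pair gives no reason to set the rise on the halogen. The value of compound 4 is a limit and not a number, the step from compound 2 to compound 4 cannot be read, and the two readable steps are floors rather than sizes because of the assay limit: the limit of > 100000 nM in this assay, at which 2 of the 4 values shown sit.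

Open, as far as these compounds go, is where between isobutyl and heptyl the number turns, for example with a butyl or pentyl chain on that ring carbon. Also open, from the compounds shown here alone, is whether an amine or a benzyl group on the same saturated ring carbon would give a lower number than compound 3 36000 nM.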